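Shortening the nitrogen substituent: from ether-bearing cyclobutyl to sec-butyl

A few compounds are considered here, and "the series" means these few. Any claim that something is new, unique, unknown or untested is made for them only; others in the source may bear on it.

Compound 1 `CCc1nc2c(-c3ccc(Cl)cc3Cl)ccnc2n1[C@H](CC)C1CC1`: 0.2 nM
Compound 2 `CCc1nc2c(-c3ccc(Cl)cc3Cl)ccnc2n1C(CCOC)C1CCC1`: 2.4 nM

Of the compounds shown here, two have been measured in an assay for binding affinity to Corticotropin releasing factor receptor (Rattus norvegicus); on this read-out higher numbers stand for weaker inhibition and lower numbers for stronger inhibition. Compound 2 has the highest of the two numbers; its nearest neighbour is compound 1, which gives 0.2 nM in this assay. Going by the values given here, the one measured step, a 12-fold higher number from compound 1 to compound 2 (1.08 log units; beyond the scatter), shows that enlarging the group on the aromatic nitrogen and adding an ether lost a good deal of binding.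

Compound 3 `CCc1nc2c(-c3ccc(Cl)cc3Cl)ccnc2n1C(C)CC` is not yet measured. It carries a smaller group at the same place: sec-butyl in place of 1-cyclobutyl-3-methoxypropyl on an aromatic nitrogen. The change goes back toward the kind of small branched alkyl seen in compound 1, but without the cyclopropyl ring. The step of a 12-fold higher number from compound 1 to compound 2 (1.08 log units; beyond the scatter) therefore bears on it, and in reverse, so a clear drop in the number is expected, although the loss of the ring leaves some doubt about how far the drop goes.

Compound 3 is expected to reach about 0.8 nM in this assay, within 0.25 nM to 3 nM, which would mean a step of a 3.0-fold lower number from compound 2 to compound 3 (0.48 log units; beyond the scatter).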

Compound 3, inhibition constant: 1.3 nM
For compound 3 the middle estimate is 1.6-fold (0.21 log units) below the measured one, and the stated range covers the measured number.
By their numbers in this assay, from the lowest: compound 1; then compounds 3 and 2 (each within the scatter of the next).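

In this assay, going by these compounds alone, sec-butyl in place of 1-cyclobutyl-3-methoxypropyl on the aromatic nitrogen gives a 1.8-fold lower number from compound 2 to compound 3 (0.27 log units; within the scatter), so these two groups cannot be told apart here, even though only one carries a ring and an ether oxygen. Within the data shown here, a small branched group alone is also not enough to match compound 1, as sec-butyl in place of 1-cyclopropylpropyl gives a 6.5-fold higher number from compound 1 to compound 3 (0.81 log units; beyond the scatter), which leaves 1-cyclopropylpropyl as the one group of the three that stands apart. No measurement is available that would explain these differences.

The compounds shown do not separate the contribution of the ring from that of the methoxy-bearing chain, a question that a 1-cyclobutylpropyl or a 1-cyclopropyl-3-methoxypropyl group on the same nitrogen would address. As far as these compounds go, it also remains open how this assay would respond to an amine or a hydroxyl group in place of the methoxy group, or to a cyclopentyl ring in place of the cyclopropyl ring of compound 1.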